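Fluoro for bromo in a caffeoyl-linked triazole series

The source may hold more compounds than are shown below. What is called first, only, known or untested is meant among the compounds shown, and "the series" means these compounds.

Compound 1 `CS(=O)(=O)c1ccc(-c2nc(SCCCOC(=O)/C=C/c3ccc(O)c(O)c3)nn2-c2ccc(Br)cc2)cc1` and compound 2 `CS(=O)(=O)c1ccc(-c2nc(SCCCOC(=O)/C=C/c3ccc(O)c(O)c3)nn2-c2ccc(F)cc2)cc1` share one core and differ only by fluoro in place of bromo on an aromatic carbon. In a functional assay on B16-F10 cells (Mus musculus) for antiproliferative activity, read by MTT assay, with a stated time of 72 h (on this read-out higher numbers stand for weaker inhibition and lower numbers for stronger inhibition), compound 1 gives 13100 nM, and compound 2 gives 10400 nM; the step is a 1.3-fold lower number from compound 1 to compound 2 (0.10 log units; within the scatter). Compound 3 `CC(=O)Oc1ccc(/C=C/C(=O)NCCCSc2nc(-c3ccc(S(C)(=O)=O)cc3)n(-c3ccc(Br)cc3)n2)cc1OC(C)=O` carries a different core, and how the two cores differ is not broken down here. In this assay compound 3 gives 16400 nM, which stands within the scatter of both compound 1 and compound 2, so no order among the three is claimed. Compound 4 `CC(=O)Oc1ccc(/C=C/C(=O)NCCCSc2nc(-c3ccc(S(C)(=O)=O)cc3)n(-c3ccc(F)cc3)n2)cc1OC(C)=O` is not yet measured; it differs from compound 3 by fluoro in place of bromo on an aromatic carbon, the same change as between compound 1 and compound 2, at a place described in the same words. Since that change gave a 1.3-fold lower number from compound 1 to compound 2 (0.10 log units; within the scatter), a step of similar size, within the scatter, is expected on the second core as well. Compound 4 is expected to give 13000 nM, with a range of 6000 nM to 30000 nM. For compound 4 the expected step is a 1.3-fold lower number from compound 3 to compound 4 (0.10 log units; within the scatter).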

Compound 4, half-maximal inhibitory concentration: 15200 nM
The estimate for compound 4 lay 1.2-fold (0.07 log units) below the measured number, within the range that was stated.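

In this assay, 4-fluorophenyl in place of 4-bromophenyl on the second core gives a 1.1-fold lower number from compound 3 to compound 4 (0.03 log units; within the scatter), so the step stays small here as it did on the core of compound 1. Set side by side, the two steps do not separate: the same change on two cores in this assay, a 1.3-fold lower number (0.10 log units; within the scatter) from compound 1 to compound 2 and a 1.1-fold lower number (0.03 log units; within the scatter) from compound 3 to compound 4, 1.2-fold (0.07 log units) apart, within the scatter of two such steps. Going by these compounds alone, this shows that the change behaves alike on these two cores in the plain sense that neither step leaves the scatter, but it does not show that the change has any real effect on either core, and with only two pairs it gives neither a rule for the whole series nor a test of how a step of real size would carry over.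

On these data alone, whether a different group at this place on the aromatic ring, such as chloro, methoxy or a carboxylic acid, would give a step beyond the scatter stays open. Also open, as far as these compounds go, is what a longer chain in the linker would do on either core.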